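The source may hold more compounds than are shown below. What is called first, only, known or untested is meant among the compounds shown, and "the series" means these compounds.

The three measured compounds, with their results in an ADME assay on A549 cells (Homo sapiens) for cytotoxicity, read by resazurin assay, with a stated time of 48 h; on this read-out lower numbers stand for higher toxicity in this test and higher numbers for lower toxicity in this test:
compound 1 `O=C(Nc1ccc(NCC2CC2)cc1Cl)c1cc(Cl)ccc1O` gives 14400 nM
compound 2 `O=C(Nc1ccc(NCc2ccccc2)cc1Cl)c1cc(Cl)ccc1O` gives 19700 nM
compound 3 `CN(C)c1ccc(CNc2ccc(NC(=O)c3cc(Cl)ccc3O)c(Cl)c2)cc1` gives 24500 nM

Compound 1 sits at the low end of these three numbers, yet the steps that separate it from the others, a 1.4-fold higher number from compound 1 to compound 2 (0.14 log units; within the scatter) and a 1.7-fold higher number from compound 1 to compound 3 (0.23 log units; within the scatter), are both within the scatter, so the three compounds cannot be ranked on this read-out. The step of a 1.2-fold higher number from compound 2 to compound 3 (0.09 log units; within the scatter) is likewise within the scatter.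

Compound 4 `O=C(Nc1ccc(NCc2cccnc2Cl)cc1Cl)c1cc(Cl)ccc1O` has not yet been measured. Compared with compound 1 the change is 2-chloropyridin-3-yl in place of cyclopropyl on a saturated chain carbon bound to a nitrogen on an aromatic ring. Among the compounds with values here, the steps that bear on it are those from compound 1 to compound 2 and from compound 1 to compound 3, in which cyclopropyl was also replaced by an aromatic ring at the same place, and each gave a small rise that stayed within the scatter. The step from compound 2 to compound 3 shows that a substituent on such a ring changed little as well. Compound 4 is therefore expected to show a 1.2-fold higher number from compound 1 to compound 4 (0.07 log units; within the scatter), a step not beyond the scatter. The estimate for compound 4 in this assay is 17000 nM, expected to lie between 8000 nM and 36000 nM.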

Compound 4, half-maximal cytotoxic concentration: 101000 nM
The estimate for compound 4 lay 5.9-fold (0.77 log units) below the measured number, outside the stated range (above it).
By their numbers in this assay, from the lowest: compounds 1, 2 and 3 (each within the scatter of the next); then compound 4.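

In this assay, the group on a saturated chain carbon bound to a nitrogen on an aromatic ring now moves the number beyond the scatter, with 2-chloropyridin-3-yl in place of cyclopropyl giving a 7.0-fold higher number from compound 1 to compound 4 (0.85 log units; beyond the scatter) in a step that the earlier replacements of cyclopropyl did not match. Compound 4 also stands apart from both earlier aromatic members, with a 5.1-fold higher number from compound 2 to compound 4 (0.71 log units; beyond the scatter) and a 4.1-fold higher number from compound 3 to compound 4 (0.62 log units; beyond the scatter) showing that an aromatic ring at this place does not by itself settle the number, since phenyl and 4-(dimethylamino)phenyl stayed within the scatter of cyclopropyl while 2-chloropyridin-3-yl did not. Nothing at hand accounts for this rise, so the reason for it remains unexplained.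

The step from phenyl to 2-chloropyridin-3-yl brings in both a ring nitrogen and a chlorine, and the compounds shown cannot separate the two, which a pyridin-3-yl or a 2-chlorophenyl group at the same place would address. On these data alone, it also remains open whether other groups here, such as 2-chloropyridin-4-yl or a 2-fluoropyridin-3-yl ring, would give a number like that of compound 4 or one like those of compounds 1, 2 and 3.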